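Shortening the side chain beside the hydroxyurea group

The source may hold more compounds than are shown below. What is called first, only, known or untested is meant among the compounds shown, and "the series" means these compounds.

Three compounds share the same core, a hydroxyurea attached to a chain carbon that carries a triple bond leading into an aromatic amide. Compound 1 `C[C@H](C#Cc1cccc(C(=O)NCCC(c2ccc(F)cc2)c2ccc(C(F)(F)F)cc2)c1)N(O)C(N)=O` gives 220 nM in an assay for inhibition of Polyunsaturated fatty acid 5-lipoxygenase (Homo sapiens), read by HPLC, with stated times of 15 min and 10 min; a lower number here means a stronger inhibitor, a higher number a weaker inhibitor. Compound 3 `CC(C#Cc1cccc(C(=O)NCCC(c2ccccc2)c2ccc(C(F)(F)F)cc2)c1)N(O)C(N)=O` gives 150 nM in this assay. Compound 2 `CC(C)CC(C#Cc1cccc(C(=O)NCc2ccccc2C(F)(F)F)c1)N(O)C(N)=O` gives 600 nM in this assay, the highest of the three numbers; its gaps to compound 1 and to compound 3 both lie beyond the usual scatter, so compound 2 is the weakest inhibitor of the three measured.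

Compound 4 `CC(C#Cc1cccc(C(=O)NCc2ccccc2C(F)(F)F)c1)N(O)C(N)=O` has not yet been measured. It differs from compound 2 in one place: hydrogen in place of isopropyl on a saturated chain carbon, two bonds along the chain from an amide-type nitrogen and a triple-bonded carbon. Among the measured compounds shown here, compound 1 and compound 3 also carry only a methyl at this chain carbon and give lower numbers than compound 2, but they differ from compound 2 in the amide portion as well, so no single measured step isolates this change. With that in mind, the step of a 1.5-fold lower number from compound 2 to compound 4 (0.18 log units; within the scatter) is expected to be a modest move toward a lower number, possibly not beyond the scatter. Compound 4 is therefore estimated at 400 nM, with a likely range from 150 nM to 1000 nM.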

Compound 4, half-maximal inhibitory concentration: 700 nM
Estimate against measurement, compound 4: 1.8-fold (0.24 log units) below, and the stated range covers the measured number.
By their numbers in this assay, from the lowest: compounds 3 and 1 (each within the scatter of the next); then compounds 2 and 4 (each within the scatter of the next).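

In this assay, hydrogen in place of isopropyl on a saturated chain carbon, two bonds along the chain from an amide-type nitrogen and a triple-bonded carbon, gives a 1.2-fold higher number from compound 2 to compound 4 (0.07 log units; within the scatter). This is the first step among the compounds shown that isolates this position, as the earlier compounds also differ in the amide portion, and it shows that going from isobutyl to methyl at this carbon, with the loss of 3 carbon atoms, produces no change that can be told apart from the usual variation between repeated measurements. No measurement here offers an explanation for this result.

Going by these compounds, the step is known only with the amide portion that compound 2 and compound 4 share, so whether the same change would give a similar result with the amide portion of compound 1 or compound 3 remains open. Also open, on these data alone, is how this assay would read with a longer chain at this carbon, or with a chain ending in an amine or a carboxylic acid.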